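Restoring a sulfur-bearing chain on the shared core

This account rests on a few compounds, and the source may have more. Where it says the series, first, only, none or still open, it means among the compounds named here.

Compound 2 `Nc1ncnc2c1nc(O)n2Cc1ccccc1` gives 30 mg/kg in a functional assay on the whole organism for activation, with Mus musculus as the target (a higher number here means that more compound is needed for the effect, a lower number that less compound is needed), the highest of the two numbers recorded so far. Its nearest neighbour, compound 1 `CCCSc1nc(N)c2nc(O)n(Cc3ccccc3)c2n1`, gives 0.1 mg/kg in this assay. Going by the values given here, the single measured step that bears on the next change is a 300-fold higher number from compound 1 to compound 2 (2.48 log units; beyond the scatter), a large move that goes with the loss of the propylsulfanyl group. Compound 3 `CCCC[S+]([O-])c1nc(N)c2nc(O)n(Cc3ccccc3)c2n1` differs from compound 2 by a group of 6 heavy atoms (4 carbon, 1 oxygen, 1 sulfur; no ring) in place of a hydrogen atom, on an aromatic carbon, so a chain holding sulfur returns to the very position where the earlier removal cost so much. The step in this assay is therefore expected to be large and toward a lower number, with the entering group being different in length and in oxygen content from the one that left, so the full return is uncertain. Compound 3 is estimated at 0.3 mg/kg, within 0.05 mg/kg to 3 mg/kg, an expected step of a 100-fold lower number from compound 2 to compound 3 (2.00 log units; beyond the scatter).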

Compound 3, minimum effective dose: 1 mg/kg
For compound 3 the middle estimate is 3.3-fold (0.52 log units) below the measured one; low and high end bracket the measured number.
By their numbers in this assay, from the lowest: compound 1; then compound 3; then compound 2.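

In this assay, the aromatic carbon between two ring nitrogen atoms does not depend on propylsulfanyl alone: a different sulfur-bearing chain also recovers much of what the bare hydrogen lost, with a 30-fold lower number from compound 2 to compound 3 (1.48 log units; beyond the scatter). The recovery is only partial, however, since replacing propylsulfanyl with the group of 6 heavy atoms gives a 10-fold higher number from compound 1 to compound 3 (1.00 log units; beyond the scatter), so the two chains are not interchangeable at this position. The data give no account of what lies behind either step.

The entering group differs from propylsulfanyl in both its carbon count and its oxygen, so the share of each in the step remains unresolved. On these data alone, it also remains open whether sulfur is needed at all, as a plain butyl chain or an amine at this carbon would show.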